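Swapping an Amide for a Thiophene Ester on the Shared Core

The source may hold more compounds than are shown below. What is called first, only, known or untested is meant among the compounds shown, and "the series" means these compounds.

Of the compounds shown here, three have been tested in an assay on COS-1 cells for displacement of a labelled ligand from sodium-dependent dopamine transporter (Homo sapiens); a lower number here means a stronger inhibitor, a higher number a weaker inhibitor. Compound 1 `O=C(C1=C(c2ccc(Cl)c(Cl)c2)CCC1)N1CCCC1` gives 58000 nM, and compound 2 `CCN(CC)C(=O)C1=C(c2ccc(Cl)c(Cl)c2)CCC1` gives 94000 nM. Compound 3 `O=C(Oc1ccccc1)C1=C(c2ccc(Cl)c(Cl)c2)CCC1` gives 170 nM. Of the three numbers, compound 1 stands second highest: its nearest neighbour is compound 2, and the step from one to the other 1.6-fold higher number from compound 1 to compound 2 (0.21 log units; within the scatter) is within the scatter, so no order between them can be read. The furthest is compound 3, reached by a step of a 340-fold lower number from compound 1 to compound 3 (2.53 log units; beyond the scatter) that is large and well beyond the scatter; the matching step a 550-fold lower number from compound 2 to compound 3 (2.74 log units; beyond the scatter) is of similar size.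

Compound 4 `O=C(OCc1cccs1)C1=C(c2ccc(Cl)c(Cl)c2)CCC1` has not been measured. It differs from compound 1 in one place: (thiophen-2-yl)methoxy in place of pyrrolidin-1-yl on a carbonyl carbon. The two measured steps that bear on this change are the replacements of an amine on the carbonyl carbon by an oxygen-linked group, which in this assay lowered the number by the large steps of a 340-fold lower number from compound 1 to compound 3 (2.53 log units; beyond the scatter) and a 550-fold lower number from compound 2 to compound 3 (2.74 log units; beyond the scatter). Compound 4 carries the same kind of replacement, although its oxygen-linked group is not the phenoxy of compound 3, so the size is less certain. Compound 4 is therefore expected to show a large step downward, a 150-fold lower number from compound 1 to compound 4 (2.16 log units; beyond the scatter), and its estimated value is 400 nM, within a range of 60 nM to 3000 nM.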

Compound 4, inhibition constant: 400 nM
Compound 4: middle estimate and measured number agree at the digits printed; the range from low to high includes it.
By their numbers in this assay, from the lowest: compound 3; then compound 4; then compounds 1 and 2 (each within the scatter of the next).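

In this assay, the large drop on leaving the amides is not tied to phenoxy alone: (thiophen-2-yl)methoxy on the same carbonyl carbon also gives a 150-fold lower number from compound 1 to compound 4 (2.16 log units; beyond the scatter) and, against the other amide, a 240-fold lower number from compound 2 to compound 4 (2.37 log units; beyond the scatter) on the same shared core. The choice of oxygen-linked group still counts, though on a much smaller scale, since replacing phenyl by (thiophen-2-yl)methyl on the ester oxygen gives a 2.4-fold higher number from compound 3 to compound 4 (0.37 log units; beyond the scatter) and this modest step lies just beyond the scatter. No measurement shown here accounts for either the wide gap between the esters and the amides or the smaller gap between the two esters.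

This last change swaps the ring and adds a carbon link in one move, so the compounds shown leave open which of the two lies behind the modest step, a question that a benzyloxy group on the carbonyl carbon would help to separate. They also leave open whether the oxygen-linked group needs a ring at all, which a plain methoxy group in this place would test.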